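The source may report more compounds than this note shows. Statements on the series, on what has been measured and on what is new or still open speak of the compounds shown alone.

In an ADME assay on WRL68 cells (Homo sapiens) for cytotoxicity (a lower number here means a stronger inhibitor, a higher number a weaker inhibitor), compound 3 (`CO[C@H]1C=C(COC(C)=O)C(=O)[C@H](O)[C@H]1O`) gives > 200000 nM, which is a limit of the assay and not a number. Compound 1 (`CC(=O)OCC1=C[C@H](OCc2ccc3ccccc3c2)[C@H](O)[C@@H](O)C1=O`) gives > 200000 nM, which is also a limit. Compound 3 therefore stands at the limit of > 200000 nM in this assay, at which 2 of the 3 values shown sit. Only compound 2 (`CC(=O)OCC1=C[C@H](OCc2ccc(-c3ccccc3)cc2)[C@H](O)[C@@H](O)C1=O`) gives an actual number, 71300 nM. Compound 4 (`CCCO[C@H]1C=C(COC(C)=O)C(=O)[C@H](O)[C@H]1O`) turns the methoxy of compound 3 into propoxy: ethyl in place of hydrogen on a saturated chain carbon bound to an oxygen on a saturated carbon. Compound 2 carries a far larger group and still reads 71300 nM, so only a small step toward a lower number, or none beyond the scatter, is expected in this assay. The expected step is a number no higher from compound 3 to compound 4 (the limit leaves the size open). For compound 4, the estimated value is 200000 nM, with an expected range from 90000 nM to 400000 nM.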

Compound 4, half-maximal inhibitory concentration: 191000 nM
For compound 4 the middle estimate is 1.0-fold (0.02 log units) above the measured one, and the stated range covers the measured number.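

In this assay, turning methoxy into propoxy gives an at least 1.0-fold lower number from compound 3 to compound 4 (0.01 log units; that floor lies within the scatter). For the compounds shown here, this is the first step that can be read at this position, and it shows that adding ethyl to this short chain need not move the number beyond the scatter. Compound 4 gives an actual number while compound 3 has only a limit, and the true size of the step stays unknown because so many values sit at that ceiling: the limit of > 200000 nM in this assay, at which 2 of the 4 values shown sit.

Still open, on these data alone, is whether a much longer chain, or an amine at the end of this chain, would clearly lower the number.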